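This account rests on a few compounds, and the source may have more. Where it says the series, first, only, none or still open, it means among the compounds named here.

Measured compounds and their values in a physicochemical assay for lipophilicity, in phosphate buffer, measured as octanol-water partition, with a stated time of 24 h; a lower number here means a more polar compound, a higher number a more lipophilic compound:

Compound 1, `Clc1ccc(Oc2ccc(/C=N/Nc3nc4ccccc4s3)cc2)cc1`: 5.6
Compound 2, `O=C(CSc1nc2ccccc2s1)N/N=C1\C(=O)Nc2ccccc21`: 3.2
Compound 3, `Cc1ccc(Oc2ccc(/C=N/NC(=O)CSc3nc4ccccc4s3)cc2)cc1`: 5.7

Among these three numbers, compound 1 stands second highest in this assay. Its nearest neighbour is compound 3, whose value sits so close that the two are within the usual scatter of this measurement and cannot be told apart. The value of compound 2 lies far below, well beyond the scatter.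

The step considered here leads from compound 1 to compound 4, `Brc1ccc(Oc2ccc(/C=N/Nc3nc4ccccc4s3)cc2)cc1`, which has not yet been measured in this assay. The two structures differ in one place only:

bromo in place of chloro on an aromatic carbon

Among the measured compounds shown here, no pair of measured compounds differing in a single place is available, so there is no measured step to lean on. A change of this kind, one halogen exchanged for another on an aromatic carbon with nothing else touched, would normally be expected to shift the partition coefficient only slightly, if at all, and in the direction of the higher number. The step of a number 0.15 log units higher from compound 1 to compound 4 (within the scatter) is therefore expected to stay within the scatter of the measurement. Compound 4 is expected to give about 5.75 in this assay, most likely between 5.4 and 6.1.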

Compound 4, partition coefficient: 5.5
The estimate for compound 4 lay 0.25 log units above the measured number; low and high end bracket the measured number.
By their numbers in this assay, from the lowest: compound 2; then compounds 4, 1 and 3 (each within the scatter of the next).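

Among the compounds shown here, the exchange of chloro for bromo, on an aromatic carbon of a six-membered aromatic ring of carbon only and para to a large group, gives a number 0.10 log units lower from compound 1 to compound 4 (within the scatter) in this assay and provides the first measured step that differs in one place. It shows that, at this position and on the core of compound 1, the 4-chlorophenoxy and 4-bromophenoxy forms cannot be told apart by this partition measurement, so these two halogens are interchangeable here as far as this read-out can resolve. Nothing measured alongside these values accounts for the size of this step, and no explanation can be offered from the data at hand.

This single exchange says nothing about how the partition coefficient in this assay would respond if a group of a different kind, such as fluoro, methoxy, an amine or a carboxylic acid, stood at the same position. Whether the same exchange of chloro for bromo would give a similar step on a different core also remains open, as no second pair of this kind is shown.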